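The source may hold more compounds than are shown below. What is called first, only, known or untested is meant among the compounds shown, and "the series" means these compounds.

Working notes on the series. In a functional assay on the whole organism with Mus musculus as the target (a higher number here means that more compound is needed for the effect, a lower number that less compound is needed), compound 1 `Cc1cc([C@@H]2C[C@H]2C(=O)O)ccc1-c1noc(-c2ccc(OC(C)C)c(C(F)(F)F)c2)n1` gives 0.2 mg/kg, and one further entry carries no single number. Compound 2 `Cc1cc([C@@H]2C[C@H]2C(=O)O)ccc1-c1noc(-c2ccc(OC(C)C)c(C#N)c2)n1` gives 0.3 mg/kg; 0.2 mg/kg; 0.2 mg/kg (3 entries), within the scatter of compound 1. Compound 3 `Cc1cc(CC(C)C(=O)O)ccc1-c1noc(-c2ccc(OC(C)C)c(C(F)(F)F)c2)n1` differs from compound 1 by 2-carboxypropyl in place of 2-carboxycyclopropyl on an aromatic carbon. Within the data shown here, no measured step covers this change, so from compound 1 at 0.2 mg/kg a moderate step towards more compound needed is expected in this assay. The estimated step is a 2.5-fold higher number from compound 1 to compound 3 (0.40 log units; beyond the scatter). For compound 3 the expected dose is 0.5 mg/kg, with an estimated range of 0.15 mg/kg to 1.5 mg/kg.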

Compound 3, dose for half-maximal effect: 0.1 mg/kg
Beside the measured number, compound 3's estimate is 5.0-fold (0.70 log units) above it; the measured number lies below the stated range.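

Exchanging 2-carboxycyclopropyl for 2-carboxypropyl on this aromatic carbon gives a 2.0-fold lower number from compound 1 to compound 3 (0.30 log units; within the scatter), so in this assay the data do not separate the open chain from the three-membered ring. At this position, the ring and its defined stereocentres are therefore not needed for a dose in this range. Repeat entries for one compound show how far such doses vary: the several entries of compound 2 in this assay, 0.3 mg/kg; 0.2 mg/kg; 0.2 mg/kg (3 entries)

Open, on these data alone, is how this position responds when an amine or a primary amide stands in place of the carboxylic acid. Also open, as far as these compounds go, is the effect of a longer chain carrying the carboxylic acid.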